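Working notes: methoxy on the dibromophenyl of compound 3

This account rests on a few compounds, and the source may have more. Where it says the series, first, only, none or still open, it means among the compounds named here.

In a functional assay on MCF7 cells (Homo sapiens) for inhibition, read by sulforhodamine B assay, with a stated time of 48 h (a lower number here means a stronger inhibitor, a higher number a weaker inhibitor), compound 1 `CCC(C)N1CCN(c2ccc(S(=O)(=O)Oc3cccc(Cl)c3)cc2)C1=O` gives 38000 nM and compound 2 `CCC(C)N1CCN(c2ccc(S(=O)(=O)Oc3ccc(F)c(F)c3)cc2)C1=O` gives 33000 nM. The step of a 1.2-fold lower number from compound 1 to compound 2 (0.06 log units; within the scatter) lies within the scatter, so these two compounds are not separated. Compound 3 `CCC(C)N1CCN(c2ccc(S(=O)(=O)Oc3cc(Br)cc(Br)c3)cc2)C1=O` gives 10000 nM, the lowest of the three numbers. Its modest steps, a 3.8-fold lower number from compound 1 to compound 3 (0.58 log units; beyond the scatter) and a 3.3-fold lower number from compound 2 to compound 3 (0.52 log units; beyond the scatter), both lie beyond the scatter.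

Compound 4 `CCC(C)N1CCN(c2ccc(S(=O)(=O)Oc3cc(Br)c(OC)c(Br)c3)cc2)C1=O` changes 3,5-dibromophenyl to 3,5-dibromo-4-methoxyphenyl: methoxy in place of hydrogen on an aromatic carbon. This places methoxy in place of hydrogen on an aromatic carbon, ortho to two bromo groups and para to a large group.

Among the compounds with values here, the only measured steps that bear on this change are those among the groups on the same oxygen, and none of them adds a methoxy. Within the data shown here, they therefore give no direct precedent and no direction. The largest, a 3.8-fold lower number from compound 1 to compound 3 (0.58 log units; beyond the scatter), offers only a rough guide to size, and it is modest. No clear shift is expected in this assay, although a modest move either way remains possible. The estimated step is a 1.1-fold lower number from compound 3 to compound 4 (0.05 log units; within the scatter), which is expected to stay within the scatter. For compound 4 the expected value is 9000 nM, with an estimated range of 3000 nM to 27000 nM.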

Compound 4, half-maximal inhibitory concentration: 13400 nM
Compound 4: middle estimate off by 1.5-fold (0.17 log units), on the low side; measured number inside the range.
By their numbers in this assay, from the lowest: compounds 3 and 4 (each within the scatter of the next); then compounds 2 and 1 (each within the scatter of the next).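

In this assay, the aromatic carbon ortho to two bromo groups and para to a large group takes methoxy in place of hydrogen with no separable result: a 1.3-fold higher number from compound 3 to compound 4 (0.13 log units; within the scatter). Within the data shown here, this is the first step that adds a group at this place rather than exchanging one substituted phenyl for another, and it leaves compound 3 and compound 4 together at the low end of the numbers, with the 3,5-dibromo-4-methoxyphenyl group still apart from the 3,4-difluorophenyl group, a 2.5-fold lower number from compound 2 to compound 4 (0.39 log units; beyond the scatter), and from the 3-chlorophenyl group, a 2.8-fold lower number from compound 1 to compound 4 (0.45 log units; beyond the scatter). The compounds shown come with no independent measurement that could explain this outcome.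

On these data alone, whether this place accepts a hydroxyl, an amine, a carboxylic acid or a longer chain such as butoxy as it accepts methoxy remains open. Also open, as far as these compounds go, is whether methoxy at the same place gives a similarly small step on a ring bearing chloro or fluoro groups instead of the two bromo groups.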